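This account rests on a few compounds, and the source may have more. Where it says the series, first, only, none or still open, it means among the compounds named here.

Measured so far:
compound 1, `O=C(Cc1c[nH]c2ccccc12)NCCC1CCN(Cc2ccccc2)CC1`: 0.1 10^-6 cm/s
compound 2, `Cn1cc(CC(=O)NCCC2CCN(Cc3ccccc3)CC2)c2ccccc21`: 5.5 10^-6 cm/s

Among the compounds with values here, of the two numbers in an ADME assay for permeability, using PAMPA, with a stated time of 8 h, tested at 500 uM (on this read-out higher numbers stand for higher permeability and lower numbers for lower permeability), compound 1 stands lowest; the nearest is compound 2, and the step between them, a 55-fold higher number from compound 1 to compound 2 (1.74 log units; beyond the scatter), is the only step measured so far. Compound 3, `O=C(Cc1c[nH]c2ccc(Br)cc12)NCCC1CCN(Cc2ccccc2)CC1`, differs from compound 1 by bromo in place of hydrogen on an aromatic carbon. Within the data shown here, the single measured step concerns the aromatic nitrogen of the core and not an aromatic carbon, so no measured step bears directly on the change to compound 3, and the series offers no guide to its size. The expected step is a 3.0-fold higher number from compound 1 to compound 3 (0.48 log units; beyond the scatter), upward rather than downward and at most slightly beyond the scatter. Compound 1 gives 0.1 10^-6 cm/s, which leaves little room below. Compound 3 is estimated in this assay at 0.3 10^-6 cm/s, with a range from 0.08 10^-6 cm/s to 1.2 10^-6 cm/s.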

Compound 3, apparent permeability: 0.5 10^-6 cm/s
Compound 3: middle estimate off by 1.7-fold (0.22 log units), on the low side, and the stated range covers the measured number.
By their numbers in this assay, from the lowest: compound 1; then compound 3; then compound 2.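

In this assay bromo in place of hydrogen on an aromatic carbon of the six-membered aromatic ring of carbon only gives a 5.0-fold higher number from compound 1 to compound 3 (0.70 log units; beyond the scatter) and so shows that the read-out responds to a change at this carbon of the shared core, not only at the aromatic nitrogen. This step is modest, while a 55-fold higher number from compound 1 to compound 2 (1.74 log units; beyond the scatter) is large, so the nitrogen change remains the larger of the two changes made to compound 1. Nothing at hand gives a reason for the step at this position.

On these data alone, whether chloro, methoxy or an amine on the same aromatic carbon would give a step of similar size remains open. Also open, as far as these compounds go, is whether bromo at this carbon gives a similar step in compound 2, where methyl stands on the aromatic nitrogen.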